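Leaving the 4-isopropylpiperazin-1-yl group: compound 3 to compound 4

This account rests on a few compounds, and the source may have more. Where it says the series, first, only, none or still open, it means among the compounds named here.

The series shares one core and varies a single group on an aromatic carbon. In an ADME assay (liver) for metabolic stability, with Liver microsome (Homo sapiens) as the target, using microsomes (a lower number here means that the compound disappears faster, a higher number that the compound lasts longer), compound 1 `CCc1nc2cc(Cl)ccn2c1C(=O)NCc1ccc(-c2ccc(C)cc2)cc1` gives 0.423 h, and compound 2 `CCc1nc2cc(Cl)ccn2c1C(=O)NCc1ccc(N2CCCCC2)cc1` gives 0.22 h. The step between them is a 1.9-fold lower number from compound 1 to compound 2 (0.28 log units; within the scatter).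

In this assay compound 3 `CCc1nc2cc(Cl)ccn2c1C(=O)NCc1ccc(N2CCN(C(C)C)CC2)cc1` gives > 2 h, which is a limit of the assay and not a number. That reading is the limit of > 2 h in this assay, at which 1 of the 3 values shown sits. Its true half-life is therefore unknown.

Compound 4 `CCc1nc2cc(Cl)ccn2c1C(=O)NCc1ccc(-n2cc3c(c2)CCCC3)cc1` differs from compound 3 at one place, on an aromatic carbon of a six-membered aromatic ring of carbon only: a group of 9 heavy atoms (8 carbon, 1 nitrogen; one five-membered aromatic ring with 1 hetero atom, one six-membered non-aromatic ring of carbon only) in place of a group of 9 heavy atoms (7 carbon, 2 nitrogen; one six-membered non-aromatic ring with 2 hetero atoms), on an aromatic carbon.

Among the measured compounds shown here, two measured steps bear on this change, both entering the group that compound 4 gives up. They are an at least 4.7-fold higher number from compound 1 to compound 3 (0.67 log units; beyond the scatter) and an at least 9.0-fold higher number from compound 2 to compound 3 (0.95 log units; beyond the scatter). Among the three measured compounds, only compound 3 carries 4-isopropylpiperazin-1-yl, and only compound 3 stands apart. Compound 4 loses that group, so its number is expected to fall back towards those of compound 1 and compound 2, and a clear drop beyond the scatter is expected. The expected step is an at least 6.6-fold lower number from compound 3 to compound 4 (0.82 log units; beyond the scatter). From the compounds shown here alone, its true size stays open, since one end of it rests on a limit. For compound 4 the estimate is 0.3 h, with an expected range from 0.12 h to 0.8 h.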

Compound 4, half-life: 0.455 h
Beside the measured number, compound 4's estimate is 1.5-fold (0.18 log units) below it, and the stated range covers the measured number.
By their numbers in this assay, from the lowest: compounds 2, 1 and 4 (each within the scatter of the next, the first and the last beyond it). At a limit, above all of these: compound 3.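

In this assay, the change gives an at least 4.3-fold lower number from compound 3 to compound 4 (0.64 log units; beyond the scatter), so among the compounds shown only the one carrying 4-isopropylpiperazin-1-yl stands apart, even against a group with the same heavy-atom count. The new group gives a 1.1-fold higher number from compound 1 to compound 4 (0.03 log units; within the scatter) and a 2.1-fold higher number from compound 2 to compound 4 (0.32 log units; beyond the scatter), which leaves compound 4 within the scatter of compound 1 but beyond it from compound 2, so a fused pair of rings on this aromatic carbon does not reproduce what the piperazine-bearing compound shows. The reading for compound 3 is still a limit of the assay and not a number: the limit of > 2 h in this assay, at which 1 of the 4 values shown sits.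

The compounds shown do not separate the parts of 4-isopropylpiperazin-1-yl, so the isopropyl group, the second ring nitrogen and the piperazine ring cannot be told apart as the feature that goes with compound 3 standing apart. From the compounds shown here alone, a morpholine or a 4-methylpiperazin-1-yl group on this aromatic carbon would bear on that question, while the true size of the step from the piperazine-bearing compound stays open as long as one end of it rests on a limit.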